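The compounds below may be only part of what the source reports. "The series", "measured", "known", "first", "only" and "open" are said of these compounds alone.

Compound 1 `CCOC(=O)c1sc(-c2cccc(NC(=O)c3ccc(C(C)(C)C)cc3)c2)nc1Nc1ccc(N2CCN(C)CC2)cc1` stands lowest of the two compounds measured in a functional assay on Ramos cells (Homo sapiens) for antiproliferative activity, read by CCK-8 assay, with a stated time of 72 h, tested at 40 uM (a lower number here means less inhibition, a higher number more inhibition at the concentration tested (going by the name of the read-out)), where compound 1 gives 21.2%. Compound 2 `CCOC(=O)c1sc(-c2cccc(NC(=O)c3cccc(F)c3)c2)nc1Nc1ccc(N2CCN(C)CC2)cc1` gives 85.2%. Among the measured compounds shown here, the one measured step, a number 64 percentage points higher from compound 1 to compound 2 (beyond the scatter), replaces the same group that changes in the new compound. Compound 3 `CCOC(=O)c1sc(-c2cccc(NC(=O)c3ccc(F)c(Cl)c3)c2)nc1Nc1ccc(N2CCN(C)CC2)cc1` differs from compound 1 by 3-chloro-4-fluorophenyl in place of 4-(tert-butyl)phenyl on a carbonyl carbon. For the measured compounds named here, since the only comparable step was large and upward, a sizeable rise is expected, though how far the 3-chloro-4-fluorophenyl group follows the 3-fluorophenyl group is uncertain. Compound 3 is therefore estimated at 65% in this assay, between 35% and 90%, an expected step of a number 43.8 percentage points higher from compound 1 to compound 3 (beyond the scatter).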

Compound 3, a percentage reported as inhibition, at one concentration (the size of the read-out at that concentration, not a potency): 72.5%
Estimate against measurement, compound 3: 7.5 percentage points below; the measured number falls inside the stated range.
By their numbers in this assay, from the lowest: compound 1; then compound 3; then compound 2.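

In this assay, the large gain at this carbonyl carbon is not confined to the 3-fluorophenyl group: exchanging 4-(tert-butyl)phenyl for 3-chloro-4-fluorophenyl gives a number 51.3 percentage points higher from compound 1 to compound 3 (beyond the scatter) as well. The two halogen-bearing phenyl groups are not interchangeable, however, with a number 12.7 percentage points lower from compound 2 to compound 3 (beyond the scatter) between them. No evidence is available that bears on either step. From the compounds shown here alone, whether the modest drop belongs to the chlorine or to the fluorine of the 3-chloro-4-fluorophenyl group stays open, as does how an unsubstituted phenyl, or a phenyl carrying an amine or a carboxylic acid, would behave here.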